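The compounds below may be only part of what the source reports. "The series", "measured", "known", "first", "only" and "open" are said of these compounds alone.

The measured compounds in an assay on isolated protein for inhibition of RAC-alpha serine/threonine-protein kinase (Homo sapiens), read by Z'-LYTE, with a stated time of 1 h, in the presence of a further agent that is not named here; on this read-out higher numbers stand for weaker inhibition and lower numbers for stronger inhibition:

Compound 1 `CC(C)(C)OC(=O)NN(Cc1ccccc1)C(=O)CCl` gives > 100000 nM, which is a limit rather than a number.
Compound 2 `CC(C)(C)OC(=O)NN(Cc1ccccc1)C(=O)CI` gives 16100 nM.
Compound 3 `C=CC(=O)N(Cc1ccccc1)NC(=O)OC(C)(C)C` gives > 100000 nM, again a limit rather than a number.

Compound 2 therefore stands alone as the only one of the three with a real number; the other two sit at the limit, as the limit of > 100000 nM in this assay, at which 2 of the 3 values shown sit, records. All three share the same core and differ only in the group carried on the carbonyl carbon. Compound 4 `CC(C)(C)OC(=O)NN(Cc1ccccc1)C(=O)CN1C(=O)C=CC1=O` changes that group once more: a group of 7 heavy atoms (4 carbon, 1 nitrogen, 2 oxygen; one five-membered non-aromatic ring with 1 hetero atom) in place of one iodine atom, on a saturated chain carbon bound to a carbonyl carbon.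

Within the data shown here, two measured steps touch this position. Going from chlorine to iodine produced an at least 6.2-fold lower number from compound 1 to compound 2 (0.79 log units; beyond the scatter), and exchanging the iodomethyl group for a vinyl group produced an at least 6.2-fold higher number from compound 2 to compound 3 (0.79 log units; beyond the scatter). The remaining pair, a step that the two limits leave unreadable from compound 1 to compound 3, adds nothing readable. Every group other than iodomethyl tried at this position has returned only a limit, so a new group of unknown behaviour is more likely to weaken than to strengthen inhibition.

Compound 4 is therefore expected to give a higher number than compound 2, roughly a 3.1-fold higher number from compound 2 to compound 4 (0.49 log units; beyond the scatter), with a real chance of landing at the limit. The estimate for compound 4 is 50000 nM, expected within 10000 nM to 200000 nM.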

Compound 4, half-maximal inhibitory concentration: 4680 nM
For compound 4 the middle estimate is 11-fold (1.03 log units) above the measured one, and the stated range ends above it.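

In this assay, replacing the iodine atom with the group of 7 heavy atoms, which holds a five-membered non-aromatic ring, gives a 3.4-fold lower number from compound 2 to compound 4 (0.54 log units; beyond the scatter), so a group far larger than one iodine atom is compatible with inhibition on this saturated chain carbon bound to a carbonyl carbon and even improves on iodo. Among these compounds, the gaps to the chloro and vinyl versions are wider, at an at least 21-fold lower number from compound 1 to compound 4 (1.32 log units; beyond the scatter) and an at least 21-fold lower number from compound 3 to compound 4 (1.32 log units; beyond the scatter), which shows that iodomethyl is no longer the only group here to give a readable number. Only compound 1 and compound 3 now stay without a real number, each sitting at a limit: the limit of > 100000 nM in this assay, at which 2 of the 4 values shown sit.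

What the compounds shown leave open is which part of the new group matters, the ring as a whole or the double bond inside it, since only one ring-bearing group appears here. The same ring without that double bond would begin to separate the two, while a simple amine or a longer chain at this place would show how far the gain extends beyond this single group.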